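This account rests on a few compounds, and the source may have more. Where it says the series, first, only, none or still open, it means among the compounds named here.

Measured so far in a functional assay on MOLT-4 cells (Homo sapiens) for antiproliferative activity, with a stated time of 48 h; a higher number here means a weaker inhibitor, a lower number a stronger inhibitor:
compound 1, `COc1ccc(/C=C/C(=O)c2ccc(N)cc2)c(OC)c1`, 20000 nM
compound 2, `COc1cc(/C=C/C(=O)c2ccc(N)cc2)cc(OC)c1`, 7500 nM
compound 3, `COc1cc(/C=C/C(=O)c2ccc(N)cc2)cc(OC)c1OC`, 5600 nM

Compound 1 has the highest number of the three; compound 2 and compound 3 both sit lower by more than the scatter. Compound 1 and compound 2 share the same atoms joined differently, and the difference between the two cores is not broken down here, so nothing is said about its size beyond what the two values show.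

From compound 2 to compound 3 the change is methoxy in place of hydrogen on an aromatic carbon and it gives a 1.3-fold lower number from compound 2 to compound 3 (0.13 log units; within the scatter), a step within the scatter.

Compound 4, `COc1ccc(/C=C/C(=O)c2ccc(N)cc2)c(OC)c1OC`, is not yet measured. It differs from compound 1 by methoxy in place of hydrogen on an aromatic carbon. This is the same kind of change as from compound 2 to compound 3, not the same: in compound 3 the new group stands para to a large group, in compound 4 meta to a large group.

Resting on the small step of a 1.3-fold lower number from compound 2 to compound 3 (0.13 log units; within the scatter), the step of a 1.4-fold lower number from compound 1 to compound 4 (0.15 log units; within the scatter) is expected to be small as well. For compound 4 in this assay the estimate is 14000 nM, likely between 6000 nM and 35000 nM.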

Compound 4, half-maximal inhibitory concentration: 10000 nM
Beside the measured number, compound 4's estimate is 1.4-fold (0.15 log units) above it; measured number inside the range.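

In this assay, methoxy in place of hydrogen on an aromatic carbon gives a 2.0-fold lower number from compound 1 to compound 4 (0.30 log units; within the scatter), so on the core of compound 1 the step is as small as the one seen on the core of compound 2. Set side by side, the two steps do not differ: the same change on two cores in this assay, a 1.3-fold lower number (0.13 log units; within the scatter) from compound 2 to compound 3 and a 2.0-fold lower number (0.30 log units; within the scatter) from compound 1 to compound 4, 1.5-fold (0.17 log units) apart, within the scatter of two such steps. Going by these compounds alone, this shows only that the change carried across these two cores with no visible difference in size; since both steps lie within the scatter, it does not show that the added methoxy lowers the number on either core, and two cores give no rule for the wider series.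

Still open, from the compounds shown here alone, is whether a group other than methoxy on that aromatic carbon, such as a hydroxyl or a longer chain like ethoxy, would give a step beyond the scatter. Also open, going by these compounds, is what an amide or a carboxylic acid in place of the amine would do to the number in this assay.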